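The source may hold more compounds than are shown below. What is called first, only, known or untested is meant among the compounds shown, and "the series" means these compounds.

Compound 3 `O=C(Nc1ccc(-n2ccc3nc(C(=O)NCc4ccccc4)ccc32)cc1)Nc1cccc(C(F)(F)F)c1` gives 7900 nM in a functional assay on A375P cells (Homo sapiens) for cytotoxicity, read by MTT assay (a higher number here means a weaker inhibitor, a lower number a stronger inhibitor), the highest of the three numbers in hand. Compound 1 `O=C(Nc1ccc(-n2ccc3nc(C(=O)NCc4ccccc4)ccc32)cc1)Nc1ccc(Cl)c(C(F)(F)F)c1` gives 1100 nM in this assay, and compound 2 `COC(=O)c1ccc2c(ccn2-c2ccc(NC(=O)c3ccc(Cl)c(C(F)(F)F)c3)cc2)n1` gives 3000 nM. Among the compounds with values here, the only single-point step measured runs from compound 1 to compound 3, where hydrogen in place of chloro on an aromatic carbon gave a 7.2-fold higher number from compound 1 to compound 3 (0.86 log units; beyond the scatter).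

Compound 4 `O=C(Nc1ccc(-n2ccc3nc(C(=O)NCc4ccccc4)ccc32)cc1)c1ccc(Cl)c(C(F)(F)F)c1` differs from compound 3 by 4-chloro-3-(trifluoromethyl)phenyl in place of (3-(trifluoromethyl)phenyl)amino on a carbonyl carbon. This brings back the chloro that compound 1 carries, while also replacing the urea linkage with an amide. The chloro part of the change has a measured counterpart, the reverse of the step from compound 1 to compound 3; the urea-to-amide part has none, and compound 2, which carries an amide and the same chloro and trifluoromethyl pattern but a different group on the core, gives only its own number, not a step. On that basis a fall in number beyond the scatter is expected, of about a 5.3-fold lower number from compound 3 to compound 4 (0.72 log units; beyond the scatter), landing compound 4 near compound 1. Compound 4 is estimated at 1500 nM in this assay, with a range from 500 nM to 5000 nM.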

Compound 4, half-maximal inhibitory concentration: 700 nM
Beside the measured number, compound 4's estimate is 2.1-fold (0.33 log units) above it; measured number inside the range.
By their numbers in this assay, from the lowest: compounds 4 and 1 (each within the scatter of the next); then compound 2; then compound 3.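

Replacing the (4-chloro-3-(trifluoromethyl)phenyl)amino group on the carbonyl carbon with 4-chloro-3-(trifluoromethyl)phenyl, which turns the urea into an amide, stays within the scatter in this assay (a 1.6-fold lower number from compound 1 to compound 4 (0.20 log units; within the scatter)), so the urea nitrogen and its hydrogen are not needed for this pair. The larger change (an 11-fold lower number from compound 3 to compound 4 (1.05 log units; beyond the scatter)) alters both the linkage and the chloro, so this step alone cannot divide it between them. Within the data shown here, at the other end of the molecule, benzylamino in place of methoxy on a carbonyl carbon gives the first reading of that position (a 4.3-fold lower number from compound 2 to compound 4 (0.63 log units; beyond the scatter)).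

Nothing available explains these steps. Still open, as far as these compounds go, is whether a carboxylic acid or a morpholine amide on that carbonyl carbon, or bromo in place of chloro, would hold the number.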